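The source may report more compounds than this note shows. Statements on the series, on what has been measured and on what is new or still open speak of the compounds shown alone.

Measured so far:
Compound 1, `Cc1cc(C)c(CN2CCc3c(Cl)cc([C@@H](CO)[C@@H]4CCCO4)c(Cl)c3C2=O)c(=O)[nH]1`, gives 135 nM in an assay for inhibition of histone-lysine N-methyltransferase EZH2 variant Y641N (Homo sapiens), read by scintillation counting, with a stated time of 60 min, in the presence of a further agent that is not named here; a lower number here means a stronger inhibitor, a higher number a weaker inhibitor.
Compound 2, `Cc1cc(C)c(CN2CCc3c(Cl)cc([C@@H](CO)[C@H]4CCCO4)c(Cl)c3C2=O)c(=O)[nH]1`, gives 110 nM in this assay.

Compound 2 carries the lower of the two numbers, but the gap to compound 1, a 1.2-fold lower number from compound 1 to compound 2 (0.09 log units; within the scatter), lies within the scatter, so the two compounds cannot be told apart on these data. That step rests on the fact that compounds 1 and 2 differ only in the configuration as drawn: a single ring stereocentre drawn the other way, with no effect beyond the scatter.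

Compound 3, `Cc1cc(C)c(CN2CCc3c(Cl)cc([C@H](CO)[C@@H]4CCCO4)c(Cl)c3C2=O)c(=O)[nH]1`, is the compound still to be measured. the two compounds have the same atoms and bonds and differ only in configuration as drawn: 2 of 2 stereo elements differ (all stereocentres are inverted: mirror images); a stereocentre at a saturated chain carbon is drawn S in compound 2 and R in compound 3; a stereocentre at a saturated ring carbon is drawn R in compound 2 and S in compound 3

Within the data shown here, only the step from compound 1 to compound 2 bears on this change, and it was small. It tested the ring stereocentre alone; the chain stereocentre has not been varied in any measured pair, so that half of the change has no measured guide, and the expectation must stay wide. Compound 3 is estimated at 450 nM, within 90 nM to 3000 nM. This means an expected step of a 4.1-fold higher number from compound 2 to compound 3 (0.61 log units; beyond the scatter) toward a weaker inhibitor, with little confidence in its size.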

Compound 3, inhibition constant in the histone-lysine N-methyltransferase EZH2 assay: 10 nM
The estimate for compound 3 lay 45-fold (1.65 log units) above the measured number; measured number below the stated range.
By their numbers in the histone-lysine N-methyltransferase EZH2 assay, from the lowest: compound 3; then compounds 2 and 1 (each within the scatter of the next).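

The chain stereocentre turns out to be the centre that matters in the histone-lysine N-methyltransferase EZH2 assay: redrawing it alone, with the ring stereocentre untouched, gives a 14-fold lower number from compound 1 to compound 3 (1.13 log units; beyond the scatter), so compound 3 is the most potent of the three, and the mirror-image pair shows a similar picture with an 11-fold lower number from compound 2 to compound 3 (1.04 log units; beyond the scatter). Because nothing but the drawn configuration changes, the large gain can only come from the spatial arrangement, not from any added or removed group: the fact that compounds 1 and 3 differ only in the configuration as drawn In a physicochemical assay for solubility, measured as kinetic solubility (a higher number here means a more soluble compound, a lower number a less soluble compound), compound 2 gives 576000 nM and compound 3 gives 400000 nM, a step of a 1.4-fold lower number from compound 2 to compound 3 (0.16 log units; within the scatter), so the two cannot be told apart on solubility and the gain in the histone-lysine N-methyltransferase EZH2 assay arrives with no readable change in the physicochemical assay.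

From the compounds shown here alone, the ring stereocentre has so far been turned only with the chain centre drawn S, so its effect with the chain centre drawn R, as in the one stereoisomer missing from this set, remains open. Going by these compounds, it is also open whether an amine or a carboxylic acid in place of the alcohol on the chain would keep this potency.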